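Bromine on the indole ring: cytotoxicity of compound 3

The compounds below may be only part of what the source reports. "The series", "measured", "known", "first", "only" and "open" are said of these compounds alone.

Measured compounds:
compound 1, `COc1cc(/C(Cl)=C/C=C(\C#N)C(=O)c2c[nH]c3ccccc23)cc(OC)c1OC`, 35900 nM
compound 2, `COc1ccc2[nH]cc(C(=O)/C(C#N)=C/C=C(\Cl)c3ccc(Br)cc3)c2c1`, "not determined" (no result reported)

Within the data shown here, compound 1 is the only compound with a number in an ADME assay on Vero cells (Chlorocebus sabaeus) for cytotoxicity, read by sulforhodamine B assay, with a stated time of 48 h; on this read-out lower numbers stand for stronger inhibition of growth and higher numbers for weaker inhibition of growth; compound 2 shares the same general build but gave no result in this assay, so it offers no comparison. Compound 3, `COc1cc(/C(Cl)=C/C=C(\C#N)C(=O)c2c[nH]c3ccc(Br)cc23)cc(OC)c1OC`, is not yet measured. It differs from compound 1 in one place: bromo in place of hydrogen on an aromatic carbon. Among the measured compounds shown here, no pair of measured compounds shows what such a change does, so no measured step guides the expectation. Adding a single bromine is a small change, so the expected step is a 1.4-fold lower number from compound 1 to compound 3 (0.16 log units; within the scatter). For compound 3 the expected value in this assay is 25000 nM, with a plausible range from 10000 nM to 60000 nM.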

Compound 3, concentration for total growth inhibition: 22100 nM
The estimate for compound 3 lay 1.1-fold (0.05 log units) above the measured number; the range from low to high includes it.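

In this assay, replacing 1H-indol-3-yl with 5-bromo-1H-indol-3-yl gives a 1.6-fold lower number from compound 1 to compound 3 (0.21 log units; within the scatter). Among these compounds, this is the first measured step at this position, and it shows that adding a single bromo group to this aromatic carbon leaves the two compounds indistinguishable in this test, as their difference does not exceed the normal variation between repeated measurements. No independent measurement bears on this result. As far as these compounds go, whether a larger or differently built group at the same carbon, such as an amine, a carboxylic acid or a longer chain, would produce a step beyond the scatter remains open. It is also unknown whether a bromo group on another carbon of the same ring would read the same way.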